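A Tert-Butyl Swap Carried Onto a Second Core

This account rests on a few compounds, and the source may have more. Where it says the series, first, only, none or still open, it means among the compounds named here.

Compound 1 `N#CN/C(=N\C1CCCCC1)Nc1ccncc1` was tested in a functional assay on the whole organism (blood, strain Wistar-Okamoto) with Rattus norvegicus as the target, with a stated time of 5 days (a higher number here means that more compound is needed for the effect, a lower number that less compound is needed), where compound 1 gives 20 mg/kg. Compound 2 `CC(C)(C)/N=C(\NC#N)Nc1ccncc1` differs from it in one place, (tert-butyl in place of cyclohexyl on a double-bonded nitrogen), and in this assay compound 2 gives 2.5 mg/kg. That change made a step of an 8.0-fold lower number from compound 1 to compound 2 (0.90 log units; beyond the scatter).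

Compound 3 `N#CN/C(=N\C1CCCCC1)Nc1ccccn1` keeps the cyclohexyl of compound 1 and differs from it only in the core, (pyridin-2-yl in place of pyridin-4-yl on an amine nitrogen). In this assay compound 3 gives > 35 mg/kg, and this is a limit of the assay rather than a number. Going by the values given here, compound 3 is the one compound that sits at the limit of > 35 mg/kg in this assay, at which 1 of the 3 values shown sits. Measured against compound 1, the step is an at least 1.7-fold higher number from compound 1 to compound 3 (0.24 log units; that floor lies within the scatter).

Compound 4 `CC(C)(C)/N=C(\NC#N)Nc1ccccn1` has not been measured. It stands to compound 3 as compound 2 stands to compound 1: tert-butyl in place of cyclohexyl on a double-bonded nitrogen. The place is described in the same words in both pairs, so this is the same change carried onto the core of compound 3.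

In this assay the step from compound 3 to compound 4 is expected to be an at least 4.3-fold lower number from compound 3 to compound 4 (0.64 log units; beyond the scatter), set beside the measured 8.0-fold lower number from compound 1 to compound 2 (0.90 log units; beyond the scatter), and it rests on that earlier step alone. Because compound 3 gives only > 35 mg/kg, the starting point is uncertain, and the expected number for compound 4 is estimated as 8 mg/kg, between 3 mg/kg and 35 mg/kg.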

Compound 4, minimum effective dose: > 20 mg/kg
Compound 4 ended at the assay's limit (the forecaster's own chance of this, stated with the estimate: 30%); middle value at least 2.5-fold (0.39 log units) from the limit.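

In this assay compound 4 gives > 20 mg/kg, which is a limit of the assay and not a number. Going by these compounds alone, compound 3 gives > 35 mg/kg, also a limit, so no step from compound 3 to compound 4 can be read. The compounds shown leave open whether tert-butyl in place of cyclohexyl lowers the number on the core of compound 3, as it did on the core of compound 1.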